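Sulfanyl to benzylamino swap on the diamine core

A few compounds are considered here, and "the series" means these few. Any claim that something is new, unique, unknown or untested is made for them only; others in the source may bear on it.

The series is read in a functional assay on SK-MEL-5 cells (Homo sapiens) for inhibition, read by sulforhodamine B assay, with a stated time of 48 h; on this read-out lower numbers stand for stronger inhibition of growth and higher numbers for weaker inhibition of growth. Compound 1 `Nc1cc(N)c2nc(-c3ccccc3)c(Sc3ccc(F)cc3)nc2c1` carries the (4-fluorophenyl)sulfanyl group on the shared core; in this assay compound 1 gives 33100 nM. Within the data shown here, this is the only plain number in the set, so compound 1 cannot be ranked against any other measured value. Compound 2 `CCOC(=O)[C@H](CCC(=O)O)NC(=O)c1ccc(CNc2nc3cc(N)cc(N)c3nc2-c2ccccc2)cc1` is the second measured entry. In this assay compound 2 is reported only as a limit, < 100000 nM. Compound 2 thus sits at the limit of < 100000 nM in this assay, at which 1 of the 2 values shown sits. Among the measured compounds shown here, no step between two measured compounds exists, so nothing here tells how a single change moves the read-out.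

Compound 3 `Nc1cc(N)c2nc(-c3ccccc3)c(NCc3ccc(F)cc3)nc2c1` is not yet measured. It differs from compound 1 in one place: (4-fluorobenzyl)amino in place of (4-fluorophenyl)sulfanyl on an aromatic carbon. For the measured compounds named here, with no measured step to lean on, the expected step of a 1.1-fold lower number from compound 1 to compound 3 (0.04 log units; within the scatter) is small, in no firm direction, and not beyond the usual scatter. Compound 3 is therefore expected to give about 30000 nM in this assay. The range expected for compound 3 runs from 8000 nM to 100000 nM. A limit rather than a number is also a possible outcome for compound 3.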

Compound 3, concentration for total growth inhibition: 3630 nM
Compound 3: the middle estimate sits 8.3-fold (0.92 log units) above what was measured; the measured number lies below the stated range.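

In this assay the position on the aromatic carbon next to the ring nitrogen now has its first readable step, and it shows that the read-out responds to the group held there: a 9.1-fold lower number from compound 1 to compound 3 (0.96 log units; beyond the scatter). The change replaces the sulfur link of (4-fluorophenyl)sulfanyl with the benzylic amine link of (4-fluorobenzyl)amino, adding a hydrogen-bond donor while the six-membered aromatic ring of carbon only remains, and this single step cannot assign the shift to any one of these differences. Nothing measured here explains the shift between these two compounds.

The compounds shown do not separate the effect of the nitrogen from that of the benzyl carbon, which a (4-fluorophenyl)amino or a (4-fluorobenzyl)sulfanyl group at the same position would address. Also open, as far as these compounds go, is whether the fluorine contributes to the step, and how the read-out responds to an unsubstituted benzylamino group or a longer chain between the nitrogen and the aromatic ring.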